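A ketone becomes an amide on a shared core

The compounds below may be only part of what the source reports. "The series", "measured", "known", "first", "only" and "open" are said of these compounds alone.

Of the compounds shown here, three built on one shared core have been tested in a functional assay on PC-3 cells (Homo sapiens) for antiproliferative activity, read by MTT assay, with a stated time of 48 h; a higher number here means a weaker inhibitor, a lower number a stronger inhibitor. Compound 1 `COc1cc(-c2nnc(SCC(=O)c3ccc(C(F)(F)F)cc3)n2N)cc(OC)c1OC` reaches only a limit of the assay there, > 100000 nM. Compound 2 `COc1cc(-c2nnc(SCC(=O)c3cccc(Br)c3)n2N)cc(OC)c1OC` likewise gives only a limit, > 100000 nM. Within the data shown here, compound 3 `COc1cc(-c2nnc(SCC(=O)c3ccccc3F)n2N)cc(OC)c1OC` is the single compound with a number, giving 43100 nM in this assay. It therefore stands as the one measured point among the three, the other two resting at the limit of > 100000 nM in this assay, at which 2 of the 3 values shown sit. The step of an at least 2.3-fold lower number from compound 1 to compound 3 (0.36 log units; beyond the scatter) and the step of an at least 2.3-fold lower number from compound 2 to compound 3 (0.36 log units; beyond the scatter) both favour compound 3, while a step that the two limits leave unreadable from compound 1 to compound 2 cannot be sized.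

Compound 4 `COc1cc(-c2nnc(SCC(=O)Nc3ccccc3F)n2N)cc(OC)c1OC` has not been measured. It differs from compound 3 by (2-fluorophenyl)amino in place of 2-fluorophenyl on a carbonyl carbon; cut one bond further out, a (2-fluorophenyl)carbonyl becomes a (2-fluorophenyl)carbamoyl. Among the measured compounds shown here, none of the measured steps touches this part: each exchanges one aryl group for another on the carbonyl carbon and leaves the carbonyl itself unchanged. For the measured compounds named here, no measured step thus tells the direction of this change, and the expectation rests on compound 3 alone. The step of a 1.2-fold higher number from compound 3 to compound 4 (0.06 log units; within the scatter) is expected to lie within the scatter. The estimate for compound 4 is 50000 nM, ranging from 15000 nM to 180000 nM, with a real chance that only a limit is returned.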

Compound 4, half-maximal inhibitory concentration: 36700 nM
Beside the measured number, compound 4's estimate is 1.4-fold (0.13 log units) above it; the range from low to high includes it.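

In this assay, among these compounds, placing (2-fluorophenyl)amino where 2-fluorophenyl stood on the carbonyl carbon gives a 1.2-fold lower number from compound 3 to compound 4 (0.07 log units; within the scatter), so turning the ketone into an amide, the first change here to touch the carbonyl link itself rather than only swap one aryl group for another, adds the amide hydrogen without any readable shift in the result. The 2-fluorophenyl ring therefore gives a measurable value with either link, and the amide keeps the separation from the other two aryl ketones, with an at least 2.7-fold lower number from compound 2 to compound 4 (0.43 log units; beyond the scatter) and an at least 2.7-fold lower number from compound 1 to compound 4 (0.43 log units; beyond the scatter). Compound 1 and compound 2 each remain at a limit of the assay and not at a number: the limit of > 100000 nM in this assay, at which 2 of the 4 values shown sit.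

The amide is shown with only one aryl group, so it remains open whether the same exchange would also leave the result unchanged with 3-bromophenyl or 4-(trifluoromethyl)phenyl on that link. Also open, from the compounds shown here alone, is how this assay would respond to a benzylamino group or a carboxylic acid on the carbonyl carbon, or to a methyl group on the amide nitrogen.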